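The source may report more compounds than this note shows. Statements on the series, on what has been measured and on what is new or still open speak of the compounds shown alone.

Compound 1 `COc1ncnc2c1ncn2C[C@@H]1C[C@H](O)c2ccccc21`: > 200000 nM (a limit)
Compound 2 `COc1ccc(-c2ncnc3c2ncn3C[C@@H]2C[C@H](CO)c3ccccc32)cc1`: 17600 nM

Both compounds were tested in an ADME assay on L1210/0 cells (Mus musculus) for cytotoxicity, with a stated time of 48 h; a lower number here means a stronger inhibitor, a higher number a weaker inhibitor. Compound 1 stands at > 200000 nM, and this is a limit of the assay, not a number.

Compound 2 gives an actual number, 17600 nM. Going by the values given here, the two values show only that compound 2 reaches a measurable reading while compound 1 does not.

Compound 3 `O[C@H]1C[C@@H](Cn2cnc3c(-c4ccccc4)ncnc32)c2ccccc21` keeps the core of compound 1 and changes one group, with phenyl in place of methoxy on an aromatic carbon. Among the compounds with values here, no measured pair of compounds isolates this change, so any forecast rests on thin ground. Within the data shown here, the only guide is compound 2, with its reading of 17600 nM, and a move toward stronger inhibition in this assay is therefore expected, though a modest one. The expected move is an at least 4.0-fold lower number from compound 1 to compound 3 (0.60 log units; beyond the scatter), and a result that stays at the limit of the assay remains possible. Compound 3 is estimated at 50000 nM, with an expected range from 15000 nM to 180000 nM.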

Compound 3, half-maximal inhibitory concentration: > 200000 nM
Compound 3 gave a limit, no number; the forecaster's own chance of this, stated with the estimate: 25%; middle value at least 4.0-fold (0.60 log units) from the limit.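

No step from compound 1 to compound 3 can be read in this assay, because both compounds sit at a limit of the assay and neither gives a number: the limit of > 200000 nM in this assay, at which 2 of the 3 values shown sit.

The compounds shown leave open whether phenyl in place of methoxy on an aromatic carbon changes the reading at all, and if so, in which direction and by how much.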